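Thiazole amide after the furan amides in the series

The compounds below may be only part of what the source reports. "The series", "measured", "known", "first", "only" and "open" are said of these compounds alone.

Values in a functional assay on OVCAR-5 cells (Homo sapiens) for inhibition, read by colorimetric assay and sulforhodamine B assay, with a stated time of 48 h; on this read-out higher numbers stand for weaker inhibition of growth and lower numbers for stronger inhibition of growth:
- compound 1 `CCCCCCCCCCCC[C@@H](O)[C@H]1CC[C@H]([C@H](O)CCCCCCCCCCNC(=O)c2cccs2)O1`: 2510 nM
- compound 2 `CCCCCCCCCCCC[C@@H](O)[C@H]1CC[C@H]([C@H](O)CCCCCCCCCCNC(=O)c2ccco2)O1`: 100000 nM
- compound 3 `CCCCCCCCCCCC[C@@H](O)[C@H]1CC[C@H]([C@H](O)CCCCCCCCCCNC(=O)c2ccoc2)O1`: 100000 nM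
- compound 4 `CCCCCCCCCCCC[C@@H](O)[C@H]1CC[C@H]([C@H](O)CCCCCCCCCCNC(=O)c2cncs2)O1`: not yet measured

Compound 3 is level with compound 2, and together they hold the highest of the three numbers. The next change is 1,3-thiazol-5-yl in place of furan-3-yl on a carbonyl carbon. Two large steps bear on it: a 40-fold higher number from compound 1 to compound 2 (1.60 log units; beyond the scatter) and a 40-fold higher number from compound 1 to compound 3 (1.60 log units; beyond the scatter). The two furans do not separate, with no change at the digits printed from compound 2 to compound 3 (within the scatter). The entering ring contains sulfur, as does the thiophen-2-yl of compound 1, so a large step toward lower numbers is expected in this assay. Going by the values given here, no measured compound has a ring with 2 hetero atoms, so the range stays wide. The expected step is a 10-fold lower number from compound 3 to compound 4 (1.00 log units; beyond the scatter). For compound 4 the estimate is 10000 nM, with an expected range of 2000 nM to 100000 nM.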

Compound 4, concentration for 50% growth inhibition: 100000 nM
Beside the measured number, compound 4's estimate is 10-fold (1.00 log units) below it; measured number inside the range.
By their numbers in this assay, from the lowest: compound 1; then compounds 2, 3 and 4 (each within the scatter of the next).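

In this assay a sulfur-bearing ring on this carbonyl carbon is not enough to hold the level of the thiophen-2-yl amide, with a 40-fold higher number from compound 1 to compound 4 (1.60 log units; beyond the scatter) for the change to 1,3-thiazol-5-yl. The 1,3-thiazol-5-yl amide stays level with the furan amides, showing no change at the digits printed from compound 3 to compound 4 (within the scatter) and no change at the digits printed from compound 2 to compound 4 (within the scatter) as well, so only thiophen-2-yl stands apart among these four rings. No evidence is available to explain this result.

Still open, from the compounds shown here alone, is whether thiophen-3-yl, 1,3-thiazol-2-yl or phenyl on this carbonyl carbon would come near compound 1 at 2510 nM in this series.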